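The source may hold more compounds than are shown below. What is called first, only, known or untested is meant among the compounds shown, and "the series" means these compounds.

Measured compounds: compound 1 `COc1cc2ncnc(Nc3ccc(F)c(Cl)c3)c2cc1OCCCCC(=O)Nc1ccc(S(N)(=O)=O)cc1` with 35600 nM in a functional assay on NCI-H1975 cells (Homo sapiens) for antiproliferative activity, read by MTT assay, with a stated time of 72 h (a lower number here means a stronger inhibitor, a higher number a weaker inhibitor), and compound 2 `COc1cc2ncnc(Nc3cccc(Br)c3)c2cc1OCCCCC(=O)Nc1ccc(S(N)(=O)=O)cc1` with 11400 nM.

Compound 2 stands at the lowest of the two numbers, its nearest neighbour being compound 1, separated by a 3.1-fold lower number from compound 1 to compound 2 (0.49 log units; beyond the scatter). Compound 3 `COc1cc2ncnc(Nc3cccc(F)c3)c2cc1OCCCCC(=O)Nc1ccc(S(N)(=O)=O)cc1` differs from compound 2 by fluoro in place of bromo on an aromatic carbon. Among the measured compounds shown here, the only measured step, from compound 1 to compound 2, also changes the halogen pattern on this aniline and was modest; no step changes one halogen for another. A modest rise is therefore expected, with compound 3 estimated at 25000 nM (range 10000 nM to 60000 nM), a step of a 2.2-fold higher number from compound 2 to compound 3 (0.34 log units; beyond the scatter).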

Compound 3, half-maximal inhibitory concentration: > 40000 nM
Compound 3 gave a limit, no number (the forecaster's own chance of this, stated with the estimate: 10%); at least 1.6-fold (0.20 log units) between middle value and limit.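

Among the compounds shown here, on this aromatic carbon, fluoro in place of bromo gives the first direct exchange of one halogen for another, and the number rises: an at least 3.5-fold higher number from compound 2 to compound 3 (0.54 log units; beyond the scatter). Compound 3 gives a limit of the assay and not a number: the limit of > 40000 nM in this assay, at which 1 of the 3 values shown sits. The remaining comparison is an at least 1.1-fold higher number from compound 1 to compound 3 (0.05 log units; that floor lies within the scatter), so it does not place compound 1 and compound 3 in any order.

From the compounds shown here alone, how a methyl group or a methoxy group on this carbon would compare with bromo remains open. So does whether the effect of fluoro in place of bromo would hold with a shorter chain.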